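Cyano for Methyl, Carried Onto a Second Core

The compounds below may be only part of what the source reports. "The series", "measured", "known", "first", "only" and "open" are said of these compounds alone.

Compound 1 `Cc1ccc(S(=O)(=O)N2N=C(c3ccc(N4CCN(C)CC4)cc3)CC2c2ccc(N(C)C)cc2)cc1` is the reference. In a functional assay on HCC1806 cells (Homo sapiens) for inhibition, read by sulforhodamine B assay, tested at 10 uM (a lower number here means less inhibition, a higher number more inhibition at the concentration tested (going by the name of the read-out)), compound 1 gives 32.2%. Compound 2 `CN1CCN(c2ccc(C3=NN(S(=O)(=O)c4ccc(C#N)cc4)C(c4ccc(N(C)C)cc4)C3)cc2)CC1` differs from it by cyano in place of methyl on an aromatic carbon; in this assay compound 2 gives 99.8%, and the step of a number 67.6 percentage points higher from compound 1 to compound 2 (beyond the scatter). Compound 3 `Cc1ccc(S(=O)(=O)N2N=C(c3ccc(-n4ccnc4)cc3)CC2c2ccc(N(C)C)cc2)cc1` has a different core, which differs from the core of compound 1 by 1H-imidazol-1-yl in place of 4-methylpiperazin-1-yl on an aromatic carbon. In this assay compound 3 gives 66%, so that the step of a number 33.8 percentage points higher from compound 1 to compound 3 (beyond the scatter). Compound 4 `CN(C)c1ccc(C2CC(c3ccc(-n4ccnc4)cc3)=NN2S(=O)(=O)c2ccc(C#N)cc2)cc1` is not yet measured; it differs from compound 3 by cyano in place of methyl on an aromatic carbon, the same change that turns compound 1 into compound 2, now made on the core of compound 3. Among the compounds shown this change occurs twice in all, once measured and once open. The measured instance, the step of a number 67.6 percentage points higher from compound 1 to compound 2 (beyond the scatter), carried inhibition close to completeness. A step of similar direction is expected here, a number 29 percentage points higher from compound 3 to compound 4 (beyond the scatter), smaller in size only because compound 3 already stands at 66% and inhibition cannot exceed the whole. For compound 4 the estimate in this assay is 95%, expected to fall between 80% and 100%.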

Compound 4, a percentage reported as inhibition, at one concentration (the size of the read-out at that concentration, not a potency): 4.7%
Estimate against measurement, compound 4: 90.3 percentage points above; measured number below the stated range.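

In this assay cyano in place of methyl does not carry from the core of compound 1 to the core of compound 3, where the result is a number 61.3 percentage points lower from compound 3 to compound 4 (beyond the scatter), and the two instances run in opposite directions: the same change on two cores in this assay, a number 67.6 percentage points higher (beyond the scatter) from compound 1 to compound 2 and a number 61.3 percentage points lower (beyond the scatter) from compound 3 to compound 4, 128.9 percentage points apart, beyond the scatter of two such steps

Read the other way, 1H-imidazol-1-yl in place of 4-methylpiperazin-1-yl also depends on its surroundings, since with cyano present the result is a number 95.1 percentage points lower from compound 2 to compound 4 (beyond the scatter): the same change on two cores in this assay, a number 33.8 percentage points higher (beyond the scatter) from compound 1 to compound 3 and a number 95.1 percentage points lower (beyond the scatter) from compound 2 to compound 4, 128.9 percentage points apart, beyond the scatter of two such steps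

In these compounds the two changes therefore do not add up, but this rests on a single set of four compounds at one concentration, and it does not show why the reversal occurs or whether it would hold on any other core.

From the compounds shown here alone, it remains open whether the drop belongs to cyano itself or would also appear on the core of compound 3 with another group in its place, such as chloro or methoxy. Also open, going by these compounds, is whether a different group in place of 1H-imidazol-1-yl, such as morpholin-4-yl, would side with compound 2 or with compound 4.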